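A few compounds are considered here, and "the series" means these few. Any claim that something is new, unique, unknown or untested is made for them only; others in the source may bear on it.

Compound 1 `COc1cc(N(C)C(=O)c2cccc(F)c2)cc(OC)c1OC` carries a 3-fluorophenyl on a carbonyl carbon. In a functional assay on Daoy cells (Homo sapiens) for cytotoxicity, read by MTT assay, with a stated time of 72 h (a higher number here means a weaker inhibitor, a lower number a stronger inhibitor), compound 1 gives only a limit, >= 125000 nM, not a number. Compound 2 `COc1cc(N(C)C(=O)c2cccc([N+](=O)[O-])c2)cc(OC)c1OC` also gives only a limit in this assay, >= 125000 nM. The step from compound 1 to compound 2 is unreadable, a step that the two limits leave unreadable from compound 1 to compound 2, since both sit at the limit of >= 125000 nM in this assay, at which 2 of the 2 values shown sit. Compound 3 `COc1cc(N(C)C(=O)c2ccc(F)cc2)cc(OC)c1OC` changes compound 1 by 4-fluorophenyl in place of 3-fluorophenyl on a carbonyl carbon. For the measured compounds named here, no measured step bears on this change, so no step beyond the scatter can be expected in either direction. Compound 3 is expected to give about 125000 nM, within 60000 nM to 300000 nM, most likely again only a limit. The step from compound 1 to compound 3 is expected to be a number no higher from compound 1 to compound 3 (the limit leaves the size open).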

Compound 3, half-maximal inhibitory concentration: >= 125000 nM
Compound 3: no number, only a limit; the forecaster's own chance of this, stated with the estimate: 80%; the middle value sits exactly at the limit.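

For the compounds shown here, compound 1 and compound 3 both give only a limit, so no step between them can be read: the limit of >= 125000 nM in this assay, at which 3 of the 3 values shown sit.

The compounds shown leave open whether this assay can separate 3-fluorophenyl from 4-fluorophenyl at all, and which change to the shared core would give a real number.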